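The source may hold more compounds than are shown below. What is called first, only, known or untested is meant among the compounds shown, and "the series" means these compounds.

In a physicochemical assay for solubility, in phosphate buffer, with a stated time of 18 h (a lower number here means a less soluble compound, a higher number a more soluble compound), the measured compounds are:
- compound 1 `CC(C)(C)c1ccc2c(N)c(C#N)c(N)nc2n1` gives 14200 nM.
- compound 2 `CC(C)c1ncc2c(N)c(C#N)c(N)nc2n1` gives a limit of the assay rather than a number, > 1000000 nM.
- compound 3 `CC(C)(C)c1nc(-c2cccs2)c2c(N)c(C#N)c(N)nc2n1` gives 56000 nM.

Of the two plain numbers, compound 3 stands highest, and the gap down to compound 1 lies beyond the usual scatter. The remaining value, that of compound 2, is only a limit (the limit of > 1000000 nM in this assay, at which 1 of the 3 values shown sits).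

Compound 4 `CC(C)(C)c1nc(-c2ccn[nH]2)c2c(N)c(C#N)c(N)nc2n1` differs from compound 3 in one place: 1H-pyrazol-5-yl in place of thiophen-2-yl on an aromatic carbon. Within the data shown here, no measured pair shows this change, so its effect is an expectation only. Compound 4 is expected to come out with a higher number in this assay, with an estimated step of a 2.9-fold higher number from compound 3 to compound 4 (0.46 log units; beyond the scatter), beyond the scatter. The estimate for compound 4 is 160000 nM, within a range of 50000 nM to 500000 nM.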

Compound 4, solubility: 13500 nM
The estimate for compound 4 lay 12-fold (1.07 log units) above the measured number; the whole stated range lies above it.
By their numbers in this assay, from the lowest: compounds 4 and 1 (each within the scatter of the next); then compound 3. At a limit, above all of these: compound 2.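

In this assay, 1H-pyrazol-5-yl in place of thiophen-2-yl on an aromatic carbon gives a 4.1-fold lower number from compound 3 to compound 4 (0.62 log units; beyond the scatter). This first measured step at this position shows that the number responds to the group placed there, and that a ring carrying a hydrogen-bond donor can go with the lower number. Nothing measured here explains the step.

This single pair cannot separate the effect of the donor from that of the second ring nitrogen. From the compounds shown here alone, how a phenyl ring or an amine at this position would compare remains open.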